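The source may report more compounds than this note shows. Statements on the series, on what has been measured and on what is new or still open speak of the compounds shown alone.

Compound 3 `O=C(O)c1ccccc1-c1ccc(CCc2ncc(Cc3cccc(F)c3F)[nH]2)cc1` gives 8 nM in an in vitro functional assay on cells for agonist activity at Bombesin receptor subtype-3 (Mus musculus), read by luminescence and calcium flux (on this read-out lower numbers stand for an effect already at smaller amounts and higher numbers for an effect only at larger amounts of compound), the highest of the three numbers, yet its steps to the other two compounds stay within the scatter: compound 2 `O=C(O)c1ccccc1-c1ccc(CCc2ncc(Cc3cccc(F)c3)[nH]2)cc1` gives 7.9 nM and compound 1 `O=C(O)c1ccccc1-c1ccc(CCc2ncc(CC3CCCCCC3)[nH]2)cc1` gives 5.7 nM. Compound 4 `O=C(O)c1ccccc1-c1ccc(CCc2ncc(Cc3ccc(F)cc3)[nH]2)cc1` has not yet been measured; it differs from compound 3 as follows: 4-fluorophenyl in place of 2,3-difluorophenyl on a saturated chain carbon bound to an aromatic carbon. Among the compounds with values here, the steps that bear on this change are a 1.0-fold higher number from compound 2 to compound 3 (0.01 log units; within the scatter), where a fluoro replaces a hydrogen on an aromatic carbon, and a 1.4-fold higher number from compound 1 to compound 2 (0.14 log units; within the scatter) together with a 1.4-fold higher number from compound 1 to compound 3 (0.15 log units; within the scatter), where whole ring groups are exchanged at the same saturated chain carbon. All three lie within the scatter, so compound 4 is expected to show no step beyond the scatter in this assay, namely no change at the digits printed from compound 3 to compound 4 (within the scatter). Compound 4 is therefore estimated at 8 nM, within a range from 4 nM to 16 nM.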

Compound 4, half-maximal effective concentration: 50 nM
The estimate for compound 4 lay 6.3-fold (0.80 log units) below the measured number; measured number above the stated range.
By their numbers in this assay, from the lowest: compounds 1, 2 and 3 (each within the scatter of the next); then compound 4.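

In this assay, within the data shown here, 4-fluorophenyl on a saturated chain carbon bound to an aromatic carbon brings the first steps beyond the scatter at this place: a 6.3-fold higher number from compound 3 to compound 4 (0.80 log units; beyond the scatter), a 6.3-fold higher number from compound 2 to compound 4 (0.80 log units; beyond the scatter) and an 8.8-fold higher number from compound 1 to compound 4 (0.94 log units; beyond the scatter). Cycloheptyl, 3-fluorophenyl and 2,3-difluorophenyl stay within the scatter of one another, so this place does not treat every fluorinated phenyl alike. Nothing available explains the shift.

The compounds shown leave open whether 2,4-difluorophenyl would stay near compound 3 or follow compound 4. They also leave open how 4-chlorophenyl or 4-methoxyphenyl would read at this carbon.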